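The compounds below may be only part of what the source reports. "The series", "measured", "known", "first", "only" and "open" are said of these compounds alone.

Measured so far:
compound 1 `Cc1ccccc1Nc1nc(NCc2ccncc2)ncc1Cl`, in this assay: > 100000 nM
compound 2 `Cc1ccccc1Nc1nc(Nc2ccc(N3CCN(C)CC3)cn2)ncc1Cl`, in this assay: 5980 nM

In an ADME assay on L02 cells (Homo sapiens) for inhibition, read by CCK-8 assay, with a stated time of 48 h (on this read-out lower numbers stand for stronger inhibition of growth and higher numbers for weaker inhibition of growth), compound 1 gives > 100000 nM, which is a limit of the assay and not a number. In this assay compound 2 gives 5980 nM, the only number shown in the series; the other value sits at the limit of > 100000 nM in this assay, at which 1 of the 2 values shown sits. For the measured compounds named here, compound 1 and compound 2 differ in more than one place, so no single step is available between them, and their two values show only that compound 2 yields a number where compound 1 yields a limit.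

Compound 3 `Cc1cc(C)c(Nc2nc(Nc3ccc(N4CCN(C)CC4)cn3)ncc2Cl)c(C)c1` has not yet been measured in this assay. It differs from compound 2 in one place: 2,4,6-trimethylphenyl in place of 2-methylphenyl on a nitrogen on an aromatic ring. Going by the values given here, with no measured step on which to rest, the expectation is a step of a 1.3-fold higher number from compound 2 to compound 3 (0.13 log units; within the scatter), that is, a change no larger than the usual scatter, with a slight lean toward weaker inhibition of growth. Compound 3 is therefore estimated at 8000 nM, within a range of 2500 nM to 25000 nM.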

Compound 3, concentration for 50% growth inhibition: 20500 nM
Estimate against measurement, compound 3: 2.6-fold (0.41 log units) below, within the range that was stated.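

In this assay this position gives its first readable step: (2-methylphenyl)amino to (2,4,6-trimethylphenyl)amino gives a 3.4-fold higher number from compound 2 to compound 3 (0.54 log units; beyond the scatter), so the aryl group on this nitrogen can move the read-out toward weaker inhibition of growth. The change adds carbon only, and neither group carries hydrogen-bond donors, hydrogen-bond acceptors or a net charge, so a step of this size appears here with those counts unchanged. Nothing among the data shown accounts for the step.

As far as these compounds go, because this is one step at one position, it remains open whether the trend extends to other aryl groups, such as plain phenyl or 2,6-dimethylphenyl, or to a phenyl carrying an amine or a carboxylic acid. Compound 1 gives > 100000 nM, a limit of the assay and not a number, and it differs from compound 2 in more than one place, so it cannot show how the rest of the structure bears on this change.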